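Series notes: the step from compound 1 to compound 3

The source may hold more compounds than are shown below. What is called first, only, known or untested is meant among the compounds shown, and "the series" means these compounds.

Among the compounds with values here, in a functional assay on A549 cells (Homo sapiens) for cytotoxicity, read by MTT assay, with a stated time of 72 h (on this read-out lower numbers stand for stronger inhibition and higher numbers for weaker inhibition), compound 1 `O=C1c2c[n+]([O-])c3ccccc3c2C(=O)c2c1c1ccccc1n2Cc1cn([C@@H]2C[C@H](O)[C@@H](CO)O2)nn1` gives 120 nM and holds the lower of the two numbers so far. Compound 2 `CN1CCN(CCCCCCn2c3c(c4ccccc42)C(=O)c2c[n+]([O-])c4ccccc4c2C3=O)CC1` gives 330 nM there, a gap beyond the scatter. Compound 3 `O=C1c2c[n+]([O-])c3ccccc3c2C(=O)c2c1c1ccccc1n2Cc1cn([C@@H]2O[C@H](CO)[C@@H](O)[C@H](O)[C@H]2O)nn1` remains unmeasured. Against compound 1 it carries 3,4,5-trihydroxy-6-(hydroxymethyl)oxan-2-yl in place of 4-hydroxy-5-(hydroxymethyl)oxolan-2-yl on an aromatic nitrogen of a five-membered aromatic ring with 3 nitrogen, counted as 3,4,5-trihydroxy-6-(hydroxymethyl)oxan-2-yl in place of 4-hydroxy-5-(hydroxymethyl)oxolan-2-yl on an aromatic nitrogen with the shared core untouched. Within the data shown here, no pair of measured compounds isolates this place, so the step can only be judged from the change itself. The estimated step is a 1.7-fold higher number from compound 1 to compound 3 (0.22 log units; within the scatter) toward weaker inhibition in this assay and may stay within the scatter. The estimate for compound 3 is 200 nM with 70 nM to 600 nM as its expected range.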

Compound 3, half-maximal inhibitory concentration: 560 nM
For compound 3 the middle estimate is 2.8-fold (0.45 log units) below the measured one; low and high end bracket the measured number.
By their numbers in this assay, from the lowest: compound 1; then compounds 2 and 3 (each within the scatter of the next).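

The aromatic nitrogen of the five-membered aromatic ring with 3 nitrogen is a place where the attached group matters: 3,4,5-trihydroxy-6-(hydroxymethyl)oxan-2-yl in place of 4-hydroxy-5-(hydroxymethyl)oxolan-2-yl gives a 4.7-fold higher number from compound 1 to compound 3 (0.67 log units; beyond the scatter) in this assay with the shared core untouched. Within the data shown here, this is the first pair to isolate this place, and the direction favours the five-membered ring group of compound 1 over the six-membered ring group of compound 3. Nothing available explains the step.

The change alters ring size, heavy-atom count and hydroxy substitution together, so the compounds shown do not separate these features. On these data alone, whether a 2-hydroxyethyl chain, an amine or a carboxylic acid on this nitrogen would match compound 1 remains open.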